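The compounds below may be only part of what the source reports. "The series", "measured", "known", "first", "only" and "open" are said of these compounds alone.

Measured compounds:
compound 1 `c1ccc(C(/N=C2\CCCCCN2)C2CC2)cc1`, 51%
compound 2 `c1ccc(C(/N=C2\CCCCCN2)C2CCCCC2)cc1`, 0%
compound 3 `c1csc(C/N=C2\CCCCCN2)c1`, 19%

In a functional assay on the whole organism (plasma, strain Sprague-Dawley) with Rattus norvegicus as the target, with a stated time of 2 h, at a dose of 100 mg/kg by the oral route (on this read-out lower numbers stand for a weaker effect and higher numbers for a stronger effect at the one dose given), compound 1 gives 51%, compound 2 gives 0% and compound 3 gives 19%. Compound 3 therefore stands second highest of the three numbers: compound 2 lies beyond the scatter under it and compound 1 lies beyond the scatter over it. Among the compounds with values here, the one step between measured compounds that differ in a single place is a number 51 percentage points lower from compound 1 to compound 2 (beyond the scatter), showing that the group on that carbon can swing the read-out across its whole range.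

Compound 4 `c1ccc(C(/N=C2\CCCCCN2)c2cccs2)cc1` differs from compound 3 by phenyl in place of hydrogen on a saturated chain carbon bound to an aromatic carbon and a double-bonded nitrogen. No measured step makes this same change, so the expectation can rest only on the spread shown by compound 1 and compound 2, which both carry phenyl on that carbon and differ widely in this assay. An intermediate outcome is expected, so the step of a number 16 percentage points higher from compound 3 to compound 4 (beyond the scatter) is estimated to be a moderate rise. Compound 4 is thus expected to give about 35%, within 5% to 65%.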

Compound 4, a percentage reported as inhibition, in the whole organism at one dose (the size of the read-out at that dose, not a potency): 50%
Estimate against measurement, compound 4: 15 percentage points below; the measured number falls inside the stated range.
By their numbers in this assay, from the lowest: compound 2; then compound 3; then compounds 4 and 1 (each within the scatter of the next).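

In this assay, phenyl in place of hydrogen on a saturated chain carbon bound to an aromatic carbon and a double-bonded nitrogen gives a number 31 percentage points higher from compound 3 to compound 4 (beyond the scatter), so a second ring on this carbon can raise the read-out and not only lower it. Within the data shown here, with phenyl kept on that carbon, thiophen-2-yl in place of cyclopropyl gives a number 1 percentage points lower from compound 1 to compound 4 (within the scatter), while thiophen-2-yl in place of cyclohexyl gives a number 50 percentage points higher from compound 2 to compound 4 (beyond the scatter), which leaves cyclohexyl as the one group of these three that stands apart. Nothing available explains these steps.

As far as these compounds go, it remains open whether methyl, a longer chain or an amine on this carbon would keep the read-out of the ring-bearing compounds. From the compounds shown here alone, it is also open whether the rise from phenyl would hold with a pyridine ring in place of thiophen-2-yl.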